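Furan hydrazones on Bel-7402 cells: from compound 3 to compound 4

This account rests on a few compounds, and the source may have more. Where it says the series, first, only, none or still open, it means among the compounds named here.

Measured compounds:
compound 1, `COc1ccccc1/C=N/NC(=O)c1ccc(-c2ccc(F)cc2F)o1`, 53.1%
compound 2, `O=C(N/N=C/c1ccc(-c2cccc(F)c2)o1)c1ccc(Br)cc1`, 28.2%
compound 3, `O=C(N/N=C/c1ccc(Cl)cc1)c1ccc(-c2ccccc2F)o1`, 16.9%

In a functional assay on Bel-7402 cells (Homo sapiens) for inhibition, read by sulforhodamine B assay, with a stated time of 48 h, tested at 10 uM (a lower number here means less inhibition of growth, a higher number more inhibition of growth at the concentration tested), compound 1 gives 53.1%. Compound 2 gives 28.2%, and compound 3 gives 16.9%. Compound 3 thus stands lowest of the three numbers; the nearest to it is compound 2, which lies higher by more than the scatter, and the furthest is compound 1, also higher by more than the scatter. No two of these measured compounds differ in only one place, so no single structural change within the set has a measured step attached to it.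

Compound 4, `O=C(N/N=C/c1cccc(Br)c1)c1ccc(-c2ccccc2F)o1`, differs from compound 3 as follows: 3-bromophenyl in place of 4-chlorophenyl on a carbon with a double bond to nitrogen. The rest of the molecule is kept. For the measured compounds named here, no measured pair shows a change of this kind, so nothing in the data fixes its size or direction. The step from compound 3 to compound 4 in this assay is expected to be small, a number 5.1 percentage points higher from compound 3 to compound 4 (within the scatter), and not clearly beyond the scatter in either direction, because compound 3 gives 16.9% and the unchanged remainder of the molecule is the larger part of it. Compound 4 is therefore expected to give about 22%, with a range from 5% to 45%.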

Compound 4, percent growth inhibition at one concentration: 12.5%
Compound 4: middle estimate off by 9.5 percentage points, on the high side; low and high end bracket the measured number.
By their numbers in this assay, from the lowest: compounds 4 and 3 (each within the scatter of the next); then compound 2; then compound 1.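

In this assay, for the compounds shown here, 3-bromophenyl in place of 4-chlorophenyl on a carbon with a double bond to nitrogen gives the first single-place comparison, with the rest of the molecule kept: a number 4.4 percentage points lower from compound 3 to compound 4 (within the scatter) at this position. The change alters both the halogen and where it sits on the phenyl ring, yet the two compounds are not told apart by this read-out. Nothing on hand accounts for this reading.

The compounds shown do not separate the exchange of halogen from the shift in its place, so either alone could have an effect that the other cancels. Going by these compounds, how a phenyl ring bearing an amine or a carboxylic acid would read at this position in this assay also stays open.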